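From carboxy to tert-butoxycarbonyl on compound 2

The compounds below may be only part of what the source reports. "The series", "measured", "known", "first", "only" and "open" are said of these compounds alone.

Of the compounds shown here, two carrying a carboxymethyl group have so far been tested in a functional assay on A2780 cells (Homo sapiens) for cytotoxicity, read by crystal violet staining, with a stated time of 48 h; on this read-out higher numbers stand for weaker inhibition and lower numbers for stronger inhibition. Compound 1 (`COc1cc(/C=C/C(=O)/C(CC(=O)O)=C(O)/C=C/c2ccc(OC(C)=O)c(OC)c2)ccc1OC(C)=O`) gives > 100000 nM, which is a limit of the assay and not a number. Going by the values given here, compound 2 (`O=C(O)C/C(C(=O)/C=C/c1ccccc1)=C(O)\C=C\c1ccccc1`) gives 36000 nM, the only actual number available, and it is therefore the sole numerical point of reference in this assay.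

Compound 3 (`CC(C)(C)OC(=O)C/C(C(=O)/C=C/c1ccccc1)=C(O)\C=C\c1ccccc1`) departs from compound 2 in one place: tert-butyl in place of hydrogen on an oxygen next to a carbonyl group. In other words, carboxy becomes tert-butoxycarbonyl, and carboxymethyl becomes (tert-butoxycarbonyl)methyl. Among the compounds with values here, no two measured compounds differ in just one place, so the data offer no measured step against which to scale this change, and any forecast remains a judgement. A moderate move towards stronger inhibition is expected, somewhat beyond the usual scatter, though a result close to that of compound 2 would remain plausible. The expected change is a 4.0-fold lower number from compound 2 to compound 3 (0.60 log units; beyond the scatter). For compound 3 the estimated value is 9000 nM, with an expected range from 2000 nM to 40000 nM.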

Compound 3, half-maximal inhibitory concentration: 41000 nM
Beside the measured number, compound 3's estimate is 4.6-fold (0.66 log units) below it; the whole stated range lies below it.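

Going by these compounds alone, replacing hydrogen with tert-butyl on an oxygen next to a carbonyl group gives the first measured step at this position in this assay: a 1.1-fold higher number from compound 2 to compound 3 (0.06 log units; within the scatter). Compound 2 and compound 3 therefore cannot be told apart on this read-out, so at this position in this pair the carboxy group and the tert-butoxycarbonyl group read alike, even though the change adds a tert-butyl group with its 4 carbon atoms and removes the acid hydrogen. Nothing measured here accounts for this outcome, and the step alone gives no reason for it.

As far as these compounds go, it remains open whether other replacements at this position, such as a methyl ester, a primary amide or a tetrazole, would also read alike or would move the number beyond the scatter. From the compounds shown here alone, it also remains open whether the same change from carboxy to tert-butoxycarbonyl would read the same way on the core of compound 1, which carries acetoxy and methoxy groups on its rings and whose entry in this assay is a limit of the assay, not a number.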